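This account rests on a few compounds, and the source may have more. Where it says the series, first, only, none or still open, it means among the compounds named here.

Measured compounds in a functional assay on PC-3 cells (Homo sapiens) for antiproliferative activity, read by MTT assay, with a stated time of 48 h; a higher number here means a weaker inhibitor, a lower number a stronger inhibitor:

compound 1 `O=C(Nc1cccc(C(F)(F)F)c1)Nc1nnc(Sc2ncnc3scc(-c4ccncc4)c23)s1`: 11500 nM
compound 2 `O=C(Nc1ccc(Cl)c(Cl)c1)Nc1nnc(Sc2ncnc3scc(-c4ccncc4)c23)s1`: 3600 nM
compound 3 `O=C(Nc1ccc(Cl)cc1)Nc1nnc(Sc2ncnc3scc(-c4ccncc4)c23)s1`: 7700 nM

Compound 3 stands second highest of the three numbers. Its nearest neighbour is compound 1, and the step of a 1.5-fold lower number from compound 1 to compound 3 (0.17 log units; within the scatter) lies within the scatter, so the two cannot be ordered. Its furthest neighbour is compound 2, reached through a 2.1-fold higher number from compound 2 to compound 3 (0.33 log units; beyond the scatter), a modest step beyond the scatter. The remaining pair gives a 3.2-fold lower number from compound 1 to compound 2 (0.50 log units; beyond the scatter).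

The next compound, compound 4 `COc1cccc(NC(=O)Nc2nnc(Sc3ncnc4scc(-c5ccncc5)c34)s2)c1`, differs from compound 3 by 3-methoxyphenyl in place of 4-chlorophenyl on an amide-type nitrogen. Going by the values given here, no measured step touches a methoxy group; all three measured steps exchange chloro and trifluoromethyl substituents on the same phenyl ring. Among the compounds with values here, the closest analogy is the exchange of one aryl substituent pattern for another in a 1.5-fold lower number from compound 1 to compound 3 (0.17 log units; within the scatter), which stayed within the scatter, while the only step beyond the scatter, a 2.1-fold higher number from compound 2 to compound 3 (0.33 log units; beyond the scatter), required two chloro substituents against one. On that basis the step to compound 4 is expected to stay within the scatter, with no direction that can be supported, so for compound 4 the expected step is a 1.2-fold higher number from compound 3 to compound 4 (0.07 log units; within the scatter).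

Compound 4 is therefore estimated at 9000 nM, with a range from 3500 nM to 25000 nM.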

Compound 4, half-maximal inhibitory concentration: 6800 nM
Beside the measured number, compound 4's estimate is 1.3-fold (0.12 log units) above it, within the range that was stated.
By their numbers in this assay, from the lowest: compounds 2, 4, 3 and 1 (each within the scatter of the next, the first and the last beyond it).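

In this assay, going by these compounds alone, the amide-type nitrogen now carries 3-methoxyphenyl, the first oxygen-bearing aryl group in this set, and the exchange for 4-chlorophenyl gives a 1.1-fold lower number from compound 3 to compound 4 (0.05 log units; within the scatter) with no order to be drawn between the two compounds. The other two comparisons also stay within the scatter, with a 1.9-fold higher number from compound 2 to compound 4 (0.28 log units; within the scatter) and a 1.7-fold lower number from compound 1 to compound 4 (0.23 log units; within the scatter), so compound 4 cannot be ordered against any of the three earlier compounds, even though a 3.2-fold lower number from compound 1 to compound 2 (0.50 log units; beyond the scatter) separates compound 1 and compound 2 from each other. This position therefore accepts methoxy on the phenyl ring without a readable change in this assay, and nothing measured here bears on why the result falls this way.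

The compounds shown leave open whether a substituent of a different kind on the phenyl ring, such as a dimethylamino group, a carboxylic acid or a longer alkoxy chain, would move the number in this assay beyond the scatter. They also leave open how 4-methoxyphenyl would compare with 3-methoxyphenyl at this same amide-type nitrogen, and whether replacing the phenyl ring with a saturated ring such as cyclohexyl would be accepted.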